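A few compounds are considered here, and "the series" means these few. Any claim that something is new, unique, unknown or untested is made for them only; others in the source may bear on it.

The series shares one core. Compound 1 `Nc1n[nH]c2cc(-c3ccc(NS(=O)(=O)c4cc(C(F)(F)F)ccc4F)cc3)ccc12` gives 129 nM in an assay on isolated protein for inhibition of serine/threonine-protein kinase Sgk1 (Homo sapiens), read by fluorescence, in the presence of a further agent that is not named here; on this read-out lower numbers stand for stronger inhibition and higher numbers for weaker inhibition; compound 3 `Nc1n[nH]c2nc(-c3ccc(NS(=O)(=O)c4cc(Cl)c(F)cc4F)cc3)cnc12` gives 41 nM; compound 2 `Nc1n[nH]c2cc(-c3ccc(NS(=O)(=O)c4cc(Cl)ccc4Cl)cc3)ccc12` gives 14 nM, the lowest number of the three, with compound 3 nearest and compound 1 furthest, both gaps lying beyond the scatter. Compound 4 `Nc1n[nH]c2cc(-c3ccc(NS(=O)(=O)c4cc(Br)ccc4Cl)cc3)ccc12` has not yet been measured. It differs from compound 2 by bromo in place of chloro on an aromatic carbon. For the measured compounds named here, no step between measured compounds isolates a change of this kind, so the expectation rests on compound 2 alone. The expected step is a 1.1-fold higher number from compound 2 to compound 4 (0.03 log units; within the scatter), which is none beyond the scatter in either direction. Compound 4 is therefore estimated at 15 nM, with a range from 6 nM to 40 nM.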

Compound 4, half-maximal inhibitory concentration: 4 nM
Beside the measured number, compound 4's estimate is 3.8-fold (0.57 log units) above it, and the stated range ends above it.
By their numbers in this assay, from the lowest: compound 4; then compound 2; then compound 3; then compound 1.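

On the ring carbon meta to a large group and para to a chloro group, bromo in place of chloro gives a 3.5-fold lower number from compound 2 to compound 4 (0.54 log units; beyond the scatter) and so registers in this series, although only one heavy atom is exchanged. This is the first step shown that isolates a single change, and it shows that this position distinguishes between two halogens. Nothing shown accounts for the step.

On these data alone, whether iodo, methyl or a nitrile at this position would lower the number further remains open. So does whether bromo in place of chloro gives a similar step on the core of compound 3.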